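The source may report more compounds than this note shows. Statements on the series, on what has been measured and on what is new or still open speak of the compounds shown alone.

In a functional assay on A2780 cells (Homo sapiens) for inhibition, with a stated time of 72 h (a higher number here means a weaker inhibitor, a lower number a stronger inhibitor), so far, compound 1 (`CC(=O)O[C@@]1([C@@H]2/C(C)=C(/O)C(=O)C3=C(C)[C@@H](OC(=O)[C@H](O)[C@H](C=C(C)C)NC(=O)OC(C)(C)C)C[C@@](O)([C@H]2OC(=O)c2cccc(Cl)c2)C3(C)C)CO[C@@H]1CCO`) gives 452 nM and compound 2 (`CC(=O)O[C@@]1([C@@H]2/C(C)=C(/O)C(=O)C3=C(C)[C@@H](OC(=O)[C@H](O)[C@H](CC(C)C)NC(=O)OC(C)(C)C)C[C@@](O)([C@H]2OC(=O)c2cccc(F)c2)C3(C)C)CO[C@@H]1CCO`) gives 3730 nM as its half-maximal inhibitory concentration. Compound 2 therefore holds the higher number of the two, the weaker result, and the gap between them lies beyond the usual scatter. Compound 3 (`CC(=O)O[C@@]1([C@@H]2/C(C)=C(/O)C(=O)C3=C(C)[C@@H](OC(=O)[C@H](O)[C@H](C=C(C)C)NC(=O)OC(C)(C)C)C[C@@](O)([C@H]2OC(=O)c2cccc(F)c2)C3(C)C)CO[C@@H]1CCO`) has not yet been measured. It differs from compound 2 in one place (2-methylprop-1-en-1-yl in place of isobutyl on a saturated chain carbon bound to an amide-type nitrogen and a saturated chain carbon), with 2-methylprop-1-en-1-yl in place of isobutyl on a saturated chain carbon bound to an amide-type nitrogen and a saturated chain carbon. Among the measured compounds shown here, no two measured compounds differ in only one place, so the data show no direct precedent for this step. The nearest guide is compound 1, which carries the same 2-methylprop-1-en-1-yl group and gives 452 nM as its value, although it is not a clean comparison. In this assay the step is expected to run toward a lower number and a stronger inhibitor, beyond the scatter, with a 5.3-fold lower number from compound 2 to compound 3 (0.73 log units; beyond the scatter) as its estimated size. For compound 3 the estimate is 700 nM with an expected range from 200 nM to 2500 nM for the coming measurement.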

Compound 3, half-maximal inhibitory concentration: 2220 nM
Beside the measured number, compound 3's estimate is 3.2-fold (0.50 log units) below it, and the stated range covers the measured number.
By their numbers in this assay, from the lowest: compound 1; then compounds 3 and 2 (each within the scatter of the next).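

In this assay, 2-methylprop-1-en-1-yl in place of isobutyl on a saturated chain carbon bound to an amide-type nitrogen and a saturated chain carbon gives a 1.7-fold lower number from compound 2 to compound 3 (0.23 log units; within the scatter) for this pair, so the added double bond produces no difference that this measurement can resolve. With that chain group held constant, fluoro in place of chloro on an aromatic carbon gives a 4.9-fold higher number from compound 1 to compound 3 (0.69 log units; beyond the scatter) in the same assay, which makes the halogen swap the only one of these two single changes to register beyond the usual spread of repeat measurements. Nothing available here explains either result.

The compounds shown pair isobutyl only with fluoro, so it remains open whether the same chain change would also make so little difference with chloro on the aromatic carbon. Also open, from the compounds shown here alone, is how a longer chain or an amine at this chain carbon would behave, and how bromo or methoxy would compare with fluoro and chloro on the aromatic carbon.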